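The compounds below may be only part of what the source reports. "The series", "measured", "known", "first", "only" and "open" are said of these compounds alone.

Of the compounds shown here, three built on one shared core have so far been tested in an ADME assay on MT4 cells (Homo sapiens) for cytotoxicity, read by MTT assay, with a stated time of 4 days; a higher number here means that more compound is tolerated, a lower number that less compound is tolerated. Compound 1 `Cc1cc(-c2cccc(C(F)(F)F)c2)cc(C)c1Nc1ccnc(Nc2ccc(C#N)cc2)n1` gives 4030 nM in this assay. Compound 2 `COc1ccccc1-c1cc(C)c(Nc2ccnc(Nc3ccc(C#N)cc3)n2)c(C)c1` gives 940 nM, and compound 3 `Cc1cc(-c2cccc(C#N)c2)cc(C)c1Nc1ccnc(Nc2ccc(C#N)cc2)n1` gives 920 nM. Exchanging the trifluoromethyl of compound 1 for a cyano gives a 4.4-fold lower number from compound 1 to compound 3 (0.64 log units; beyond the scatter), and replacing its 3-(trifluoromethyl)phenyl with a 2-methoxyphenyl gives a 4.3-fold lower number from compound 1 to compound 2 (0.63 log units; beyond the scatter). Between the other two the step is a 1.0-fold lower number from compound 2 to compound 3 (0.01 log units; within the scatter), so the numbers of compound 2 and compound 3 cannot be told apart, while compound 3 sits clearly below compound 1 in this assay.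

Compound 4 `Cc1cc(-c2ccccc2C(F)(F)F)cc(C)c1Nc1ccnc(Nc2ccc(C#N)cc2)n1` has not yet been measured. Relative to compound 3 it carries 2-(trifluoromethyl)phenyl in place of 3-cyanophenyl on an aromatic carbon. Within the data shown here, two measured steps bear on this: a 4.4-fold lower number from compound 1 to compound 3 (0.64 log units; beyond the scatter) and a 4.3-fold lower number from compound 1 to compound 2 (0.63 log units; beyond the scatter), both found when the 3-(trifluoromethyl)phenyl of compound 1 was removed. Among the measured compounds shown here, compound 4 brings a trifluoromethyl back, though as a 2-(trifluoromethyl)phenyl, a ring for which no measured pair exists. A step upward in this assay, back toward the number of compound 1, is therefore expected, but its size is uncertain. Compound 4 is expected to give about 2500 nM, within the range 900 nM to 7000 nM. This corresponds to an expected step of a 2.7-fold higher number from compound 3 to compound 4 (0.43 log units; beyond the scatter).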

Compound 4, half-maximal cytotoxic concentration: 4210 nM
For compound 4 the middle estimate is 1.7-fold (0.23 log units) below the measured one; the measured number falls inside the stated range.
By their numbers in this assay, from the lowest: compounds 3 and 2 (each within the scatter of the next); then compounds 1 and 4 (each within the scatter of the next).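

In this assay, shifting the trifluoromethyl from the 3-(trifluoromethyl)phenyl of compound 1 to the 2-(trifluoromethyl)phenyl of compound 4 gives a 1.0-fold higher number from compound 1 to compound 4 (0.02 log units; within the scatter), so at this aromatic carbon, meta to two methyl groups, the two trifluoromethyl rings cannot be told apart. Among these compounds, the 2-(trifluoromethyl)phenyl also stands clearly apart from the other two rings, with a 4.6-fold higher number from compound 3 to compound 4 (0.66 log units; beyond the scatter) against 3-cyanophenyl and a 4.5-fold higher number from compound 2 to compound 4 (0.65 log units; beyond the scatter) against 2-methoxyphenyl, so across these four compounds the numbers divide by the group on the ring, with no compound going against that division, and the place of the trifluoromethyl on its ring makes no readable difference. No measurement shown here accounts for this division.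

The compounds shown leave open where a plain phenyl, or a ring carrying an amine or a carboxylic acid, would fall relative to these two pairs. They also leave open whether the match between the two trifluoromethyl rings would persist if the two methyl groups on the shared core were exchanged for ethyl groups or chlorine.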